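Cyclohexyl in place of phenyl on the acylguanidine side chain

A few compounds are considered here, and "the series" means these few. Any claim that something is new, unique, unknown or untested is made for them only; others in the source may bear on it.

Within the data shown here, compound 2 `Cc1nc(N)sc1CCCNC(=N)NC(=O)C[C@H](C)c1ccccc1` gives 28.2 nM in an in vitro functional assay on Sf9 cells for agonist activity at histamine H2 receptor (Homo sapiens), read by GTPgammaS binding (on this read-out lower numbers stand for an effect already at smaller amounts and higher numbers for an effect only at larger amounts of compound), and stands with compound 1 as one of two numbers so far, both inside the usual scatter of each other. Compound 1 `Cc1nc(N)sc1CCCNC(=N)NC(=O)CC(C)c1ccccc1`, drawn without a configuration at the saturated chain carbon, gives 50.1 nM in this assay; the step of a 1.8-fold lower number from compound 1 to compound 2 (0.25 log units; within the scatter) is within the scatter, and the two structures differ only by the fact that one of compounds 1 and 2 is drawn with a defined configuration and the other without, at the place where they differ. Compound 3 `Cc1nc(N)sc1CCCNC(=N)NC(=O)CC(C)C1CCCCC1` is not yet measured in this assay. It differs from compound 2 by 1-cyclohexylethyl in place of 1-phenylethyl on a saturated chain carbon bound to a carbonyl carbon, and compound 3 carries no drawn configuration at that carbon. Among the measured compounds shown here, the only measured step, a 1.8-fold lower number from compound 1 to compound 2 (0.25 log units; within the scatter), concerns the drawing of the stereocentre and not the ring, so no measured step bears on the ring exchange. The step of a 2.1-fold higher number from compound 2 to compound 3 (0.33 log units; beyond the scatter) is therefore expected to be small and of uncertain direction, with a wide range. Compound 3 is estimated at 60 nM in this assay, between 15 nM and 250 nM.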

Compound 3, half-maximal effective concentration: 9.33 nM
For compound 3 the middle estimate is 6.4-fold (0.81 log units) above the measured one; the whole stated range lies above it.
By their numbers in this assay, from the lowest: compound 3; then compounds 2 and 1 (each within the scatter of the next).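

In this assay, the ring on the saturated chain carbon changes the number, which the earlier pair, differing only in a drawn configuration, could not show, and an aromatic ring is not required there for a low number in these compounds. With both structures drawn without a configuration, the exchange of phenyl for cyclohexyl gives a 5.4-fold lower number from compound 1 to compound 3 (0.73 log units; beyond the scatter), and the comparison with the drawn S form points the same way, with a 3.0-fold lower number from compound 2 to compound 3 (0.48 log units; beyond the scatter). Nothing at hand gives a cause for this ring exchange.

Still open, as far as these compounds go, is whether the S and R forms of compound 3 differ in this read-out. Also open, from the compounds shown here alone, is how a cyclopentyl ring or an open hexyl chain would compare with cyclohexyl at this place.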